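A Halogen Swap on the Thioether Aryl Group

The compounds below may be only part of what the source reports. "The series", "measured", "known", "first", "only" and "open" are said of these compounds alone.

Of the compounds shown here, two have been measured so far in an assay for displacement of a labelled ligand from platelet-activating factor receptor (Homo sapiens); on this read-out lower numbers stand for stronger inhibition and higher numbers for weaker inhibition. Compound 1 `CCCCN(O)C(=O)Nc1cc([C@@H]2CC[C@@H](c3cc(OC)c(OC)c(OC)c3)O2)cc(OC)c1OCCSc1ccc(Cl)cc1` gives 20 nM. Compound 2 `CCCCN(O)C(=O)Nc1cc([C@@H]2CC[C@@H](c3cc(OC)c(OC)c(OC)c3)O2)cc(OC)c1OCCSc1ccc(OC)cc1` gives 39 nM. Compound 2 has the highest of the two numbers, its nearest neighbour being compound 1; the step between them reads a 2.0-fold higher number from compound 1 to compound 2 (0.29 log units; within the scatter) and came with methoxy in place of chloro on an aromatic carbon. Compound 3 `CCCCN(O)C(=O)Nc1cc([C@@H]2CC[C@@H](c3cc(OC)c(OC)c(OC)c3)O2)cc(OC)c1OCCSc1cccc(Br)c1` has not been measured. It differs from compound 2 in this way: 3-bromophenyl in place of 4-methoxyphenyl on a sulfur. For the measured compounds named here, only the step from compound 1 to compound 2 bears on this change, and it stayed within the scatter; it shows that replacing a halogen by methoxy on this ring gave a somewhat higher number. Compound 3 carries a halogen again, so a small step toward a lower number is expected, a 1.6-fold lower number from compound 2 to compound 3 (0.19 log units; within the scatter), but nothing beyond the scatter. Compound 3 is therefore estimated at 25 nM, within a range from 10 nM to 65 nM.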

Compound 3, half-maximal inhibitory concentration: 22 nM
Compound 3: the middle estimate sits 1.1-fold (0.06 log units) above what was measured; the range from low to high includes it.
By their numbers in this assay, from the lowest: compounds 1, 3 and 2 (each within the scatter of the next).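

Compound 3 adds a third aryl group on the sulfur, and its step from the methoxy analogue is a 1.8-fold lower number from compound 2 to compound 3 (0.25 log units; within the scatter). Its step from the chloro analogue, which changes both the halogen and the ring position named, is a 1.1-fold higher number from compound 1 to compound 3 (0.04 log units; within the scatter), so in this assay 4-chlorophenyl, 4-methoxyphenyl and 3-bromophenyl cannot be told apart and the three compounds have no meaningful order. Nothing available explains why these groups read alike.

Bromine and its ring position change together here. A 4-bromophenyl or 3-chlorophenyl group would be needed to separate the two changes. On these data alone, it also remains open whether a plain phenyl, a pyridine ring, or a phenyl carrying an amine or a carboxylic acid would shift the number beyond the scatter.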